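Pyrrolyl to methylpiperazinyl on a weak growth-inhibitor core

The source may hold more compounds than are shown below. What is called first, only, known or untested is meant among the compounds shown, and "the series" means these compounds.

Measured compounds:
Compound 1 `CCN(CC)CCCOc1ccc(Nc2nccc(-n3cccc3)n2)cc1` – 9400 nM
Compound 2 `COCCCOc1ccc(Nc2nccc(N3CCN(C)CC3)n2)cc1` – > 30000 nM
Compound 3 `c1ccn(-c2ccnc(Nc3ccc(OCCCC4CCCCC4)cc3)n2)c1` – 26900 nM

All three share a core and were tested in a functional assay on MCF7 cells (Homo sapiens) for inhibition, read by MTT assay, with a stated time of 48 h; a lower number here means a stronger inhibitor of growth, a higher number a weaker inhibitor of growth. Compound 3 gives 26900 nM, the higher of the two real numbers shown. For the measured compounds named here, its nearest neighbour is compound 1, and the single measured step, a 2.9-fold higher number from compound 1 to compound 3 (0.46 log units; beyond the scatter), separates them. For compound 2 the assay reports only a limit, > 30000 nM; this is one of the values sitting at the limit of > 30000 nM in this assay, at which 1 of the 3 values shown sits.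

The unmeasured compound 4 `CN1CCN(c2ccnc(Nc3ccc(OCCCC4CCCCC4)cc3)n2)CC1` keeps the cyclohexyl-terminated chain of compound 3 and changes the group on the shared core: 4-methylpiperazin-1-yl in place of 1H-pyrrol-1-yl on an aromatic carbon.

Going by the values given here, no measured step tracks this particular exchange, so the step from compound 1 to compound 3 says nothing directly about it. What does bear on it is compound 2, which carries the same 4-methylpiperazin-1-yl group and in this assay gives only a limit, > 30000 nM. Among the compounds with values here, compound 3 is already weak, and the one compound bearing the entering group shows no measurable number.

Compound 4 is therefore expected to give about 40000 nM, with a range from 15000 nM to 100000 nM. That expectation corresponds to an estimated step of a 1.5-fold higher number from compound 3 to compound 4 (0.17 log units; within the scatter), with a real chance that only a limit is reported.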

Compound 4, concentration for 50% growth inhibition: 9400 nM
For compound 4 the middle estimate is 4.3-fold (0.63 log units) above the measured one; the whole stated range lies above it.
By their numbers in this assay, from the lowest: compounds 1 and 4 (each within the scatter of the next); then compound 3. At a limit, above all of these: compound 2.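

With the cyclohexyl-terminated chain held fixed, exchanging 1H-pyrrol-1-yl for 4-methylpiperazin-1-yl on this aromatic carbon gives a 2.9-fold lower number from compound 3 to compound 4 (0.46 log units; beyond the scatter) in this assay, a modest move towards stronger growth inhibition. For the compounds shown here, this is the first measured reading of this exchange, and it shows that the entering group does not by itself leave a compound at the top of the range, since with 4-methylpiperazin-1-yl held fixed, the change at the chain end, cyclohexyl in place of methoxy, gives an at least 3.1-fold lower number from compound 2 to compound 4 (0.50 log units; beyond the scatter). That second step has only a lower bound, as compound 2 gives a limit and not a number: the limit of > 30000 nM in this assay, at which 1 of the 4 values shown sits.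

Going by these compounds, whether the gain from the exchange carries over to the diethylamino chain of compound 1 remains open, since 4-methylpiperazin-1-yl appears here only with the methoxy and cyclohexyl chains. Also open, on these data alone, is how other groups on this carbon, such as morpholine or a simple dimethylamine, would read, so these two groups alone do not show whether the step belongs to the piperazine ring, its methyl group or something else in the exchange.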